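A furan-3-yl swap on the shared core

The source may hold more compounds than are shown below. What is called first, only, known or untested is meant among the compounds shown, and "the series" means these compounds.

compound 1 `COCC#Cc1cc(C(O)(C(F)(F)F)C(F)(F)F)cnc1N1CCN(S(=O)(=O)c2ccc(N)nc2)CC1`: 399 mL.min-1.g-1
compound 2 `CC(C)n1cc(-c2cc(C(O)(C(F)(F)F)C(F)(F)F)cnc2N2CCN(S(=O)(=O)c3ccc(N)nc3)CC2)cn1`: 198 mL.min-1.g-1

For the measured compounds named here, in an ADME assay (liver) for metabolic stability, with Liver microsome (Rattus norvegicus) as the target, using microsomes and NADPH, with a stated time of 30 min, tested at 1 uM (on this read-out higher numbers stand for fast clearance and lower numbers for slow clearance), the only measured comparison is a 2.0-fold lower number from compound 1 to compound 2 (0.30 log units; within the scatter), so compound 2 holds no clear place against compound 1. Compound 3 `Nc1ccc(S(=O)(=O)N2CCN(c3ncc(C(O)(C(F)(F)F)C(F)(F)F)cc3-c3ccoc3)CC2)cn1` carries furan-3-yl in place of 1-isopropyl-1H-pyrazol-4-yl on an aromatic carbon and is otherwise unchanged. Going by the values given here, one measured step bears on this exchange, a swap on the same aromatic carbon: a 2.0-fold lower number from compound 1 to compound 2 (0.30 log units; within the scatter). Among the compounds with values here, with only that small step to go on, the expected change is a 1.4-fold higher number from compound 2 to compound 3 (0.15 log units; within the scatter), none beyond the scatter. The estimate for compound 3 is 280 mL.min-1.g-1, with an expected range from 130 mL.min-1.g-1 to 600 mL.min-1.g-1.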

Compound 3, intrinsic clearance in microsomes: 57 mL.min-1.g-1
Beside the measured number, compound 3's estimate is 4.9-fold (0.69 log units) above it; the measured number lies below the stated range.
By their numbers in this assay, from the lowest: compound 3; then compounds 2 and 1 (each within the scatter of the next).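

In this assay, a change at this aromatic carbon moved the number beyond the scatter, which the earlier pair did not show: furan-3-yl gives a 3.5-fold lower number from compound 2 to compound 3 (0.54 log units; beyond the scatter), and against the 3-methoxyprop-1-yn-1-yl group it gives a 7.0-fold lower number from compound 1 to compound 3 (0.85 log units; beyond the scatter). Both steps run in the same direction, towards slower clearance. No evidence is available to explain the size of either step. On these data alone, it remains open whether the furan-3-yl ring itself carries the lower number, or whether a thiophen-3-yl group or a pyrazol-4-yl group without the isopropyl chain would match it.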